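From 2-hydroxyethyl to 2-hydroxypropyl on compound 1

The compounds below may be only part of what the source reports. "The series", "measured", "known", "first", "only" and "open" are said of these compounds alone.

Among the measured compounds shown here, in a physicochemical assay for lipophilicity, read by HPLC (on this read-out lower numbers stand for lower lipophilicity and higher numbers for higher lipophilicity), compound 1 `Cc1ccsc1C(=CCCN(C)C(CCO)C(=O)NCc1ccc(F)cc1)c1sccc1C` gives 5.87, the lower of the two numbers so far. For the measured compounds named here, the only other measured compound is compound 2 `Cc1ccsc1C(=CCCN(C)C(CCO)C(=O)NCc1ccc(Cl)cc1)c1sccc1C`, which gives 6.38.

Compound 3 `Cc1ccsc1C(=CCCN(C)C(CC(C)O)C(=O)NCc1ccc(F)cc1)c1sccc1C` differs from compound 1 at one place. The change is methyl in place of hydrogen on a saturated chain carbon bound to an oxygen on a saturated carbon and a saturated chain carbon, on a saturated chain carbon bound to an oxygen on a saturated carbon and a saturated chain carbon, so that 2-hydroxyethyl becomes 2-hydroxypropyl.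

Going by the values given here, the only measured step is a number 0.51 log units higher from compound 1 to compound 2 (beyond the scatter), with chloro in place of fluoro on an aromatic carbon. It lies beyond the scatter, but it concerns a different place and a different exchange. Among the compounds with values here, no measured step touches the chain, so this one serves only as a rough gauge of how large a small change can be. A rise somewhat smaller than that step is expected in this assay, though the direction rests on no direct measurement. The expected step is a number 0.33 log units higher from compound 1 to compound 3 (beyond the scatter). For compound 3 the estimate is 6.2, with an expected range of 5.85 to 6.55.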

Compound 3, partition coefficient: 5.51
Beside the measured number, compound 3's estimate is 0.69 log units above it; measured number below the stated range.
By their numbers in this assay, from the lowest: compound 3; then compound 1; then compound 2.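

In this assay, methyl in place of hydrogen on a saturated chain carbon bound to an oxygen on a saturated carbon and a saturated chain carbon turns 2-hydroxyethyl into 2-hydroxypropyl and gives a number 0.36 log units lower from compound 1 to compound 3 (beyond the scatter), so that one extra carbon on this chain goes with a lower number, not a higher one. Among the compounds shown here, this is the first reading at the chain, and its direction is opposite to that of the exchange of fluoro for chloro on an aromatic carbon, which gives a number 0.51 log units higher from compound 1 to compound 2 (beyond the scatter), so the aromatic step cannot serve as a guide to the chain. Nothing measured on these compounds bears on why the number falls at this position.

As far as these compounds go, it remains open whether the fall continues along the chain, as a 2-hydroxybutyl group would show, or whether it depends on the hydroxyl itself, as an amine in the same place would show. From the compounds shown here alone, it is also open whether 2-hydroxypropyl in place of 2-hydroxyethyl on compound 2 gives a step of the same direction and size, which would show whether the chain change holds with chloro on the aromatic ring.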